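A few compounds are considered here, and "the series" means these few. Any claim that something is new, unique, unknown or untested is made for them only; others in the source may bear on it.

In a functional assay on DLD-1 cells (Homo sapiens) for cytotoxicity, read by resazurin assay, with a stated time of 48 h (on this read-out lower numbers stand for an effect already at smaller amounts and higher numbers for an effect only at larger amounts of compound), compound 1 `COc1ccc(S(=O)(=O)Nc2ccc(-c3nc4cc(NS(=O)(=O)c5ccc(OC)cc5)ccc4o3)cc2)cc1` gives 28000 nM and compound 2 `O=S(=O)(Nc1ccc(-c2nc3cc(NS(=O)(=O)c4cccc(C(F)(F)F)c4)ccc3o2)cc1)c1cccc(C(F)(F)F)c1` gives 15000 nM. For the measured compounds named here, these two values lie within the usual scatter of each other, so compound 1 cannot be separated from the only other measured compound. Compound 3 `COc1ccc(S(=O)(=O)Nc2ccc3oc(-c4ccc(NC(=O)c5ccc(Cl)s5)cc4)nc3c2)cc1` has (5-chlorothiophen-2-yl)carbonyl in place of (4-methoxyphenyl)sulfonyl on a nitrogen on an aromatic ring. Going by the values given here, no measured pair shows this change on its own, so the expectation is uncertain. Only a small move toward a lower number, within the scatter, is expected, as the estimated 1.9-fold lower number from compound 1 to compound 3 (0.27 log units; within the scatter). For compound 3 the estimated value is 15000 nM, with an expected range from 4000 nM to 50000 nM.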

Compound 3, half-maximal effective concentration: 4600 nM
The estimate for compound 3 lay 3.3-fold (0.51 log units) above the measured number, within the range that was stated.
By their numbers in this assay, from the lowest: compound 3; then compounds 2 and 1 (each within the scatter of the next).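

Placing (5-chlorothiophen-2-yl)carbonyl on this nitrogen in place of (4-methoxyphenyl)sulfonyl gives a 6.1-fold lower number from compound 1 to compound 3 (0.78 log units; beyond the scatter) in this assay. For the compounds shown here, this is the first step to lie beyond the scatter, so the group on this nitrogen can change the number. Nothing measured here explains the shift.

As far as these compounds go, the change swaps the ring and the sulfonyl linker together, so their separate contributions remain unknown. From the compounds shown here alone, a (4-methoxyphenyl)carbonyl group on the same nitrogen would keep the ring while changing only the linker, and its effect remains open.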